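The compounds below may be only part of what the source reports. "The series", "measured", "known", "first", "only" and "open" are said of these compounds alone.

In a toxicity assay (RAW264.7 cells) for cytotoxicity, with Mus musculus as the target, read by MTT assay, with a stated time of 24 h (a lower number here means a stronger inhibitor, a higher number a weaker inhibitor), the three measured compounds gave:

compound 1 `CCCCCCCCCC(=O)c1c(O)cc(O)c([C@@H](CC(C)C)C2=C(O)C(C)(C)C(=O)C(C)(C)C2=O)c1O` — 5.1 ug/mL
compound 2 `CCCCCCCCCCCCCC(=O)c1c(O)cc(O)c([C@@H](CC(C)C)C2=C(O)C(C)(C)C(=O)C(C)(C)C2=O)c1O` — 13.1 ug/mL
compound 3 `CCCCCCCCC(=O)c1c(O)cc(O)c([C@@H](CC(C)C)C2=C(O)C(C)(C)C(=O)C(C)(C)C2=O)c1O` — 8.2 ug/mL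

Compound 3 sits between the other two on these numbers, and both of its steps stay within the scatter: a 1.6-fold higher number from compound 1 to compound 3 (0.21 log units; within the scatter) and a 1.6-fold lower number from compound 2 to compound 3 (0.20 log units; within the scatter). Among the compounds with values here, the only step beyond the scatter is a 2.6-fold higher number from compound 1 to compound 2 (0.41 log units; beyond the scatter).

Compound 4 `CCCCCCCCCCC(=O)c1c(O)cc(O)c([C@@H](CC(C)C)C2=C(O)C(C)(C)C(=O)C(C)(C)C2=O)c1O` differs from compound 3 by ethyl in place of hydrogen on a saturated chain carbon, eight bonds along the chain from a carbonyl carbon. This change is bracketed by the two steps from compound 3: one removes a methyl and one removes a pentyl at the same place, and neither moved the number beyond the scatter. Compound 1 and compound 2, however, show that a longer addition at a nearby place can shift the number, so a small rise toward compound 2 cannot be ruled out. On balance compound 4 is expected to stay within the scatter of compound 3, with an estimated step of a 1.2-fold lower number from compound 3 to compound 4 (0.07 log units; within the scatter). Compound 4 is therefore estimated at 7 ug/mL, in the range 3.5 ug/mL to 14 ug/mL.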

Compound 4, half-maximal inhibitory concentration: 11.1 ug/mL
The estimate for compound 4 lay 1.6-fold (0.20 log units) below the measured number, within the range that was stated.
By their numbers in this assay, from the lowest: compounds 1, 3, 4 and 2 (each within the scatter of the next, the first and the last beyond it).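

In this assay, ethyl in place of hydrogen on a saturated chain carbon, eight bonds along the chain from a carbonyl carbon, gives a 1.4-fold higher number from compound 3 to compound 4 (0.13 log units; within the scatter), so this addition, like the removal of methyl and of pentyl at that carbon, leaves the number within the scatter. Hydrogen in place of propyl gives a 1.2-fold lower number from compound 2 to compound 4 (0.07 log units; within the scatter), whereas methyl in place of hydrogen, nine bonds along the chain, gives a 2.2-fold higher number from compound 1 to compound 4 (0.34 log units; beyond the scatter). Compound 1 is thus set apart from compound 2 and compound 4 but not from compound 3, which goes against any steady trend along the chain.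

The compounds shown leave open whether an amine or a carboxylic acid on this chain, or a chain longer than that of compound 2, would move the number beyond the scatter. Nothing available gives a reason for these steps.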